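From piperidin-1-yl to pyrrolidin-1-yl on a shared core

This account rests on a few compounds, and the source may have more. Where it says the series, first, only, none or still open, it means among the compounds named here.

In a functional assay on HepG2 cells (Homo sapiens) for antiproliferative activity, read by MTT assay, with a stated time of 48 h (a higher number here means a weaker inhibitor, a lower number a stronger inhibitor), compound 1 `O=c1cc(-c2ccccc2)oc2cc(O)c(OCCCN3CCCCC3)c(O)c12` gives 70600 nM. Among the measured compounds shown here, this is the higher of the two numbers measured so far, which makes it the weaker inhibitor of the pair. The other measured compound, compound 2 `COc1cc2oc(-c3ccccc3)cc(=O)c2c(O)c1OCCCN1CCCCC1`, gives 22300 nM. For the measured compounds named here, the one measured step, a 3.2-fold lower number from compound 1 to compound 2 (0.50 log units; beyond the scatter), puts methyl in place of hydrogen on an oxygen on an aromatic ring, and it is modest.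

Compound 3 `O=c1cc(-c2ccccc2)oc2cc(O)c(OCCCN3CCCC3)c(O)c12` keeps the core of compound 1 and changes only the ring at the end of the chain: pyrrolidin-1-yl in place of piperidin-1-yl on a saturated chain carbon, three bonds along the chain from an oxygen on an aromatic ring. Going by the values given here, no measured pair tests a change at that place, so the methyl step offers only a rough sense of scale and no direction. With so small a swap of ring size, no step beyond the scatter is expected in this assay, and the number should stay close to that of compound 1 at 70600 nM.

The estimated value for compound 3 is 62000 nM, with an expected range from 28000 nM to 125000 nM. The expected step is a 1.1-fold lower number from compound 1 to compound 3 (0.06 log units; within the scatter).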

Compound 3, half-maximal inhibitory concentration: > 100000 nM
Compound 3 gave a limit, no number (the forecaster's own chance of this, stated with the estimate: 10%); middle value at least 1.6-fold (0.20 log units) away from the limit.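

The value of compound 3 in this assay is a limit and not a number: the limit of > 100000 nM in this assay, at which 1 of the 3 values shown sits. Among the compounds shown here, this gives the first reading at the end of the chain, where pyrrolidin-1-yl in place of piperidin-1-yl produces an at least 1.4-fold higher number from compound 1 to compound 3 (0.15 log units; that floor lies within the scatter), so the smaller ring brings no stronger inhibition here. Since only that floor is known, and it lies within the scatter, the data cannot separate a change too small to matter from a real loss of any larger size, so the result rules out a gain but does not establish a loss.

From the compounds shown here alone, how a morpholine ring or a dimethylamino group at the end of the chain would read in this assay remains open, as does the effect of a longer chain carrying either ring. Also open, going by these compounds, is whether methyl in place of hydrogen on an oxygen on an aromatic ring, the change that gave a 3.2-fold lower number from compound 1 to compound 2 (0.50 log units; beyond the scatter), would lower the number in the same way on a compound carrying pyrrolidin-1-yl.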